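Compound 3 and a swap of methoxy for fluoro

The compounds below may be only part of what the source reports. "The series", "measured", "known", "first", "only" and "open" are said of these compounds alone.

Measured in a functional assay on NCI-H520 cells (Homo sapiens) for cytotoxicity; a higher number here means a weaker inhibitor of growth, a lower number a stronger inhibitor of growth:
- Compound 1 `COc1ccc(C2=C(c3cc(OC)c(OC)c(OC)c3)CC3CCCN3C2=O)cc1O`: > 100000 nM (a limit of the assay)
- Compound 2 `COc1ccc(C2=C(c3ccc(SC)cc3)CC3CCCN3C2=O)cc1OC(=O)CNC(=O)OC(C)(C)C`: 7000 nM
- Compound 3 `COc1ccc(C2=C(c3ccc(SC)cc3)CC3CCCN3C2=O)cc1C`: 100 nM

Compound 3 has the lowest of the two actual numbers, which makes it the stronger inhibitor of growth of that pair. The value for compound 1 is a limit and not a number.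

The unmeasured compound 4 `CSc1ccc(C2=C(c3ccc(F)c(C)c3)C(=O)N3CCCC3C2)cc1` departs from compound 3 by one change: fluoro in place of methoxy on an aromatic carbon. The swap sits ortho to a methyl group and para to a large group, so that 4-methoxy-3-methylphenyl becomes 4-fluoro-3-methylphenyl.

Within the data shown here, no measured step covers this swap. The nearest is a 70-fold lower number from compound 2 to compound 3 (1.85 log units; beyond the scatter), also a change on an aromatic carbon, but it involves different groups and a far larger one leaving. It shows only that a single replacement of this kind can move the number well beyond the scatter. A smaller swap is therefore expected to give a smaller move, and the direction is a judgment, not a measured trend, with a weaker inhibitor thought more likely in this assay.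

The expected change is an 8.0-fold higher number from compound 3 to compound 4 (0.90 log units; beyond the scatter). Compound 4 is estimated at 800 nM, with an expected range from 120 nM to 6000 nM.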

Compound 4, concentration for 50% growth inhibition: 500 nM
Compound 4: middle estimate off by 1.6-fold (0.20 log units), on the high side; the range from low to high includes it.
By their numbers in this assay, from the lowest: compound 3; then compound 4; then compound 2. At a limit, above all of these: compound 1.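

In this assay, the methoxy group of compound 3 can be replaced by fluoro at a modest but real cost: a 5.0-fold higher number from compound 3 to compound 4 (0.70 log units; beyond the scatter). This is the first change shown at this position of the 4-methoxy-3-methylphenyl group, and compound 4 keeps a measurable growth inhibition of 500 nM without the methoxy group; the earlier and far larger move, a 70-fold lower number from compound 2 to compound 3 (1.85 log units; beyond the scatter), concerned a different place on that ring and so said nothing about this one. Nothing measured here explains why the swap moves the number as it does.

With only one replacement shown at this position, it remains open whether the higher number follows from the fluoro group itself or simply from the loss of methoxy, and a chlorine atom, an amine or a longer ether such as ethoxy in the same place would help separate the two. Going by these compounds, it is equally open whether the swap would give a step of similar size if the methylthio group on the other aromatic ring were replaced by a different group.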